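Swapping Cyano for Chloro at the Toxicity Limit

This account rests on a few compounds, and the source may have more. Where it says the series, first, only, none or still open, it means among the compounds named here.

Three compounds share one core and differ only in the group on the carbonyl carbon of the amide. Compound 1 `COc1ccc(-c2cnc(NC(=O)C3CCCCC3)n2C)cc1` carries a cyclohexyl there, compound 2 `COc1ccc(-c2cnc(NC(=O)c3ccccc3)n2C)cc1` a phenyl, and compound 3 `COc1ccc(-c2cnc(NC(=O)c3ccccc3C#N)n2C)cc1` a 2-cyanophenyl. In a toxicity assay on THP-1 cells (Homo sapiens) for inhibition (a lower number here means that less compound is tolerated, a higher number that more compound is tolerated), compound 1 gives only a limit of the assay, > 100000 nM. Compound 2 likewise reaches only a limit, > 100000 nM. Compound 3 too shows only a limit, > 100000 nM. Compound 3 therefore stands at the same limit as both of its neighbours, and the steps a step that the two limits leave unreadable from compound 1 to compound 2, a step that the two limits leave unreadable from compound 1 to compound 3 and a step that the two limits leave unreadable from compound 2 to compound 3 cannot be given a size, since (the limit of > 100000 nM in this assay, at which 3 of the 3 values shown sit).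

Compound 4 `COc1ccc(-c2cnc(NC(=O)c3ccccc3Cl)n2C)cc1` is not yet measured. It differs from compound 3 by chloro in place of cyano on an aromatic carbon. For the measured compounds named here, the only measured step at this position is a step that the two limits leave unreadable from compound 2 to compound 3, which brought the cyano in; it is unreadable, so neither a direction nor a size can be taken from it. Because (the limit of > 100000 nM in this assay, at which 3 of the 3 values shown sit), compound 4 is expected to sit at that limit as well. The estimate for compound 4 in this assay is 100000 nM, with a range from 40000 nM to 300000 nM. The expected step of a number no higher from compound 3 to compound 4 (the limit leaves the size open) lies within the scatter.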

Compound 4, half-maximal cytotoxic concentration: > 50000 nM
Compound 4: a limit, no number (the forecaster's own chance of this, stated with the estimate: 85%); the middle value does not contradict the limit.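

In this assay compound 4 gives > 50000 nM, which is a limit and not a number. Compound 1, compound 2 and compound 3 also give only limits, so no step between any of these compounds can be read. The compounds shown leave open how much of each is tolerated, and whether the group on the carbonyl carbon changes the result in this assay at all.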